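Dropping a Methyl Group from an Aryl Ether

A few compounds are considered here, and "the series" means these few. Any claim that something is new, unique, unknown or untested is made for them only; others in the source may bear on it.

Going by the values given here, compound 2 `COc1cc(-c2nn(-c3cccc(NC(=O)Nc4cc(C(F)(F)F)cc(C(F)(F)F)c4)c3)cc2-c2ccncc2)ccc1Cl` is the one compound here with a number in a functional assay on HOP-92 cells (Homo sapiens) for inhibition, read by sulforhodamine B assay, with a stated time of 48 h; a higher number here means that more compound is tolerated, a lower number that less compound is tolerated; in this assay compound 2 gives 4720 nM. Compound 1 `O=C(Nc1cccc(-n2cc(-c3ccncc3)c(-c3ccc(Cl)c(O)c3)n2)c1)Nc1cccc(C(F)(F)F)c1` is reported only as a limit of the assay: in this assay compound 1 gives > 32500 nM, a limit rather than a number (the limit of > 32500 nM in this assay, at which 1 of the 2 values shown sits). Among the compounds with values here, compounds 1 and 2 differ in two places, so no single step between them has been measured; the two values show only that compound 2 sits below the limit at which compound 1 stands.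

Compound 3 `O=C(Nc1cccc(-n2cc(-c3ccncc3)c(-c3ccc(Cl)c(O)c3)n2)c1)Nc1cc(C(F)(F)F)cc(C(F)(F)F)c1` has not been measured. It differs from compound 2 by hydrogen in place of methyl on an oxygen on an aromatic ring. Compound 1, which gives > 32500 nM, also carries the hydroxy group. On that footing, a step upward, toward more compound being tolerated, is expected, a 2.3-fold higher number from compound 2 to compound 3 (0.37 log units; beyond the scatter). Compound 3 is estimated at 11000 nM, with a range from 3500 nM to 35000 nM.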

Compound 3, concentration lethal to 50% of the cells: 8660 nM
Compound 3: the middle estimate sits 1.3-fold (0.10 log units) above what was measured; the measured number falls inside the stated range.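

In this assay, replacing methoxy with hydroxy gives a 1.8-fold higher number from compound 2 to compound 3 (0.26 log units; within the scatter), so this change on the oxygen leaves no difference that can be told from the scatter. With the hydroxy group kept, the other place does carry a clear step, an at least 3.7-fold lower number from compound 1 to compound 3 (0.57 log units; beyond the scatter), where trifluoromethyl stands in place of hydrogen on an aromatic carbon. That step starts from a limit and not from a number, the one reported for compound 1: the limit of > 32500 nM in this assay, at which 1 of the 3 values shown sits.

The compounds shown leave open whether a longer chain on that oxygen, or an amine in place of the hydroxy group, would also stay within the scatter of compound 2. They also leave open whether the swap from methoxy to hydroxy reads the same when the second trifluoromethyl is absent.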